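Mirror image of a phenyl-bearing iminosugar core

The compounds below may be only part of what the source reports. "The series", "measured", "known", "first", "only" and "open" are said of these compounds alone.

Measured so far:
compound 1 `OC[C@]1(c2ccccc2)NC[C@H](O)[C@H]1O` — 190 nM
compound 2 `COc1cccc([C@@]2(CO)NC[C@H](O)[C@H]2O)c1` — 108000 nM

In an assay on isolated protein for inhibition of lysosomal alpha-glucosidase (Rattus norvegicus), read by colorimetric assay (a higher number here means a weaker inhibitor, a lower number a stronger inhibitor), compound 1 gives 190 nM, the lowest of the two numbers; compound 2, which carries a methoxy in place of hydrogen on an aromatic carbon, gives 108000 nM, and that change is a 570-fold higher number from compound 1 to compound 2 (2.75 log units; beyond the scatter). Compound 3 `OC[C@@]1(c2ccccc2)NC[C@@H](O)[C@@H]1O` is the mirror image of compound 1: the two compounds have the same atoms and bonds and differ only in configuration as drawn: 3 of 3 stereo elements differ (all stereocentres are inverted: mirror images); a stereocentre at a saturated ring carbon is drawn S in compound 1 and R in compound 3; a stereocentre at a saturated ring carbon is drawn S in compound 1 and R in compound 3; a stereocentre at a saturated ring carbon is drawn S in compound 1 and R in compound 3. Among the compounds with values here, no measured step bears on this change; the only comparison at hand, from compound 1 to compound 2, concerns a substituent and not configuration, so it offers no guide. Given that the shared core of compound 1 is a mimic of a sugar, its enantiomer is expected to be recognised far less well, and a large step upward in this assay is expected, a 110-fold higher number from compound 1 to compound 3 (2.02 log units; beyond the scatter). For compound 3 an estimate of 20000 nM is made, with a range from 2000 nM to 200000 nM.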

Compound 3, half-maximal inhibitory concentration: 904000 nM
Compound 3: the middle estimate sits 45-fold (1.66 log units) below what was measured; the measured number lies above the stated range.
By their numbers in this assay, from the lowest: compound 1; then compound 2; then compound 3.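

Inverting all the stereocentres of the shared core gives a 4800-fold higher number from compound 1 to compound 3 (3.68 log units; beyond the scatter) in this assay. The earlier step, a 570-fold higher number from compound 1 to compound 2 (2.75 log units; beyond the scatter), concerned only a methoxy in place of hydrogen on an aromatic carbon; this one shows that the number also responds strongly when no group enters or leaves. The change can be put down to one thing only: the fact that compounds 1 and 3 differ only in the configuration as drawn

Since all three stereocentres change together, the compounds shown leave open how much of the step belongs to any single one of them. They also leave open how a hydroxyl, a fluorine or an amine put there instead of the methoxy would read in this assay, and whether any such group would change the number as the methoxy does.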